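Isopentyl in place of 4-fluorophenoxy on the shared core

The source may hold more compounds than are shown below. What is called first, only, known or untested is meant among the compounds shown, and "the series" means these compounds.

Compound 3 `COc1cccc(CNCCCNc2ccnc3cc(Oc4ccc(F)cc4)ccc23)c1O` gives 9.28 in a physicochemical assay for acid dissociation. Compound 2 `COc1ccc(Oc2ccc3c(NCCCNCc4cccc(OC)c4O)ccnc3c2)cc1` gives 9.28, and the step of no change at the digits printed from compound 2 to compound 3 (within the scatter) shows fluoro in place of methoxy on an aromatic carbon leaving the number where it was. Compound 3 and compound 2 thus share the lowest of the three numbers, while compound 1 `CC(C)CCc1ccc2c(NCCCNCc3ccco3)ccnc2c1` gives 9.47, a number within the scatter of compound 3.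

Compound 4 `COc1cccc(CNCCCNc2ccnc3cc(CCC(C)C)ccc23)c1O` differs from compound 3 by isopentyl in place of 4-fluorophenoxy on an aromatic carbon. Going by the values given here, no measured step isolates this exchange: compound 1 carries the isopentyl but differs from compound 3 elsewhere as well, so the two values only bound the question loosely, and the one measured step was flat. In this assay the expected step is a number 0.12 log units higher from compound 3 to compound 4 (within the scatter), small at most. Compound 4 is therefore estimated at 9.4, in the range 9.15 to 9.65.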

Compound 4, acid dissociation constant: 9.47
Compound 4: the middle estimate sits 0.07 log units below what was measured; the range from low to high includes it.
By their numbers in this assay, from the lowest: compounds 2, 3, 1 and 4 (each within the scatter of the next).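

In this assay isopentyl in place of 4-fluorophenoxy gives a number 0.19 log units higher from compound 3 to compound 4 (within the scatter) and isopentyl in place of 4-methoxyphenoxy gives a number 0.19 log units higher from compound 2 to compound 4 (within the scatter) so this aromatic carbon carries either phenoxy group or the isopentyl chain with no step beyond the scatter. With isopentyl held there, 2-hydroxy-3-methoxyphenyl in place of furan-2-yl on the saturated chain carbon bound to an amine nitrogen gives no change at the digits printed from compound 1 to compound 4 (within the scatter) and that second place also stays within the scatter.

As far as these compounds go, whether an amine or a carboxylic acid on this aromatic carbon would move the number beyond the scatter remains open. Nothing on hand accounts for how small these steps are.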